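Purine series: methoxy to methylamino on two chain lengths

This account rests on a few compounds, and the source may have more. Where it says the series, first, only, none or still open, it means among the compounds named here.

Measured so far:
Compound 1 `CCCCCCCC(CCO)n1cnc2c(OC)ncnc21` gives 15300 nM in a functional assay on HCT-116 cells (Homo sapiens) for antiproliferative activity, read by MTT assay, with a stated time of 48 h; on this read-out higher numbers stand for weaker inhibition and lower numbers for stronger inhibition.
Compound 2 `CCCCCCCC(CCO)n1cnc2c(NC)ncnc21` gives 12500 nM in this assay.
Compound 3 `CCCCCCCCCCCC(CCO)n1cnc2c(OC)ncnc21` gives 8230 nM in this assay.

The three compounds share one core and differ in two places. Between compound 1 and compound 3 the difference is butyl in place of hydrogen on a saturated chain carbon, eight bonds along the chain from an aromatic nitrogen, and the step is a 1.9-fold lower number from compound 1 to compound 3 (0.27 log units; within the scatter). Compound 3 has the lowest of the three numbers, but its gaps to compound 2 and to compound 1 are both within the scatter, so no order can be read among them.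

The change of interest is methylamino in place of methoxy on an aromatic carbon. Made once, on the core of compound 1, it gave a 1.2-fold lower number from compound 1 to compound 2 (0.09 log units; within the scatter). Compound 4 `CCCCCCCCCCCC(CCO)n1cnc2c(NC)ncnc21` carries the same change on the core of compound 3, as methylamino in place of methoxy on an aromatic carbon; the place is the same word for word in both cases, so this is the same change, made a second time.

The expectation rests on that single earlier occurrence. Among the measured compounds shown here, with only one measured example of the change and that step within the scatter, the estimated step from compound 3 to compound 4 is a 1.2-fold lower number from compound 3 to compound 4 (0.08 log units; within the scatter), small and of uncertain direction. Compound 4 is therefore expected at about 6900 nM in this assay, with a range from 3400 nM to 14000 nM that allows for the usual spread of repeated measurements of compound 3 at 8230 nM.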

Compound 4, half-maximal inhibitory concentration: 15400 nM
Estimate against measurement, compound 4: 2.2-fold (0.35 log units) below; measured number above the stated range.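

In this assay, methylamino in place of methoxy on an aromatic carbon gives a 1.9-fold higher number from compound 3 to compound 4 (0.27 log units; within the scatter) and the two occurrences of this change do not differ beyond the scatter: the same change on two cores in this assay, a 1.2-fold lower number (0.09 log units; within the scatter) from compound 1 to compound 2 and a 1.9-fold higher number (0.27 log units; within the scatter) from compound 3 to compound 4, 2.3-fold (0.36 log units) apart, within the scatter of two such steps.
Butyl in place of hydrogen on a saturated chain carbon, eight bonds along the chain from an aromatic nitrogen, gives a 1.2-fold higher number from compound 2 to compound 4 (0.09 log units; within the scatter) and this step likewise agrees with its earlier occurrence on the other core: the same change on two cores in this assay, a 1.9-fold lower number (0.27 log units; within the scatter) from compound 1 to compound 3 and a 1.2-fold higher number (0.09 log units; within the scatter) from compound 2 to compound 4, 2.3-fold (0.36 log units) apart, within the scatter of two such steps.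
Within these four compounds, then, neither change shows a dependence on the core, but every step lies within the scatter, so the data show neither that methylamino raises or lowers the number relative to methoxy nor that the core makes no difference, and two occurrences set no direction that could be carried to another core.

The compounds shown leave open how other groups on the same aromatic carbon, such as dimethylamino or ethoxy, would read in this assay and whether any such replacement would produce a step beyond the scatter. Also open, going by these compounds, is how a longer chain, or a carboxylic acid in place of the terminal hydroxyl, would read on the shared core.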